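The compounds below may be only part of what the source reports. "The series", "measured", "known", "first", "only" and "open" are said of these compounds alone.

Compound 2 `Cc1ccc(C(=O)Nc2cccc(C(F)(F)F)c2)cc1-c1ccc2c(-c3cnn(C)c3)n[nH]c2c1` gives 24.3 nM in a functional assay on NCI-H2286 cells (Homo sapiens) for antiproliferative activity, read by CCK-8 assay, with a stated time of 72 h (a higher number here means a weaker inhibitor, a lower number a stronger inhibitor), the second highest of the three numbers measured. Compound 3 `CCn1cc(-c2n[nH]c3cc(-c4cc(C(=O)Nc5cccc(C(F)(F)F)c5)ccc4C)ccc23)cn1` gives 19.8 nM in this assay, and compound 1 `Cc1ccc(C(=O)Nc2cccc(C(F)(F)F)c2)cc1-c1ccc2c(-c3ccc(N4CCN(C)CC4)cc3)n[nH]c2c1` gives 89.5 nM in this assay. Among the measured compounds shown here, the only measured step at the same place is a 1.2-fold lower number from compound 2 to compound 3 (0.09 log units; within the scatter), which stays within the scatter. Compound 4 `Cc1ccc(C(=O)Nc2cccc(C(F)(F)F)c2)cc1-c1ccc2c(-c3cnn(CC(C)O)c3)n[nH]c2c1` differs from compound 2 by 1-hydroxyethyl in place of hydrogen on a saturated chain carbon bound to an aromatic nitrogen. Because a 1.2-fold lower number from compound 2 to compound 3 (0.09 log units; within the scatter) barely moved the number, the larger group at this place is expected to leave it within the scatter too, and the step from compound 2 to compound 4 is estimated at a 1.1-fold higher number from compound 2 to compound 4 (0.03 log units; within the scatter). Compound 4 is therefore expected to give 26 nM in this assay, with a range from 10 nM to 65 nM.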

Compound 4, half-maximal inhibitory concentration: 196 nM
For compound 4 the middle estimate is 7.5-fold (0.88 log units) below the measured one, and the stated range ends below it.
By their numbers in this assay, from the lowest: compounds 3 and 2 (each within the scatter of the next); then compound 1; then compound 4.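

At this place on a saturated chain carbon bound to an aromatic nitrogen, this assay does respond to the group carried: 1-hydroxyethyl in place of hydrogen gives an 8.1-fold higher number from compound 2 to compound 4 (0.91 log units; beyond the scatter), and 1-hydroxyethyl in place of methyl gives a 9.9-fold higher number from compound 3 to compound 4 (1.00 log units; beyond the scatter). The earlier step, a 1.2-fold lower number from compound 2 to compound 3 (0.09 log units; within the scatter), showed no such response, so tolerance of methyl here does not extend to every group. No measurement available bears on the reason for this rise. The compounds shown leave open whether the hydroxyl or the chain itself accounts for the step. A plain propyl chain, or an amine in place of the hydroxyl, would separate the two.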